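Adding a third methoxy to a weak imidazoline binder

The source may report more compounds than this note shows. Statements on the series, on what has been measured and on what is new or still open speak of the compounds shown alone.

Compound 1 `c1ccc(C2=NCCN2)cc1`: 21300 nM
Compound 2 `COc1ccc(C2=NCCN2)cc1OC`: 1000000 nM

In an assay on brain for binding affinity to Amine oxidase [flavin-containing] B (Rattus norvegicus), read by spectrophotometry (a lower number here means a stronger inhibitor, a higher number a weaker inhibitor), compound 1 gives 21300 nM, while compound 2 gives 1000000 nM, the higher of the two numbers and far above compound 1. Compound 3 `COc1cc(C2=NCCN2)cc(OC)c1OC` differs from compound 2 by methoxy in place of hydrogen on an aromatic carbon, placed ortho to a methoxy group and meta to a group of 5 heavy atoms. Since compound 2 already sits at 1000000 nM, the added methoxy is expected to bring no step beyond the scatter, so no change at the digits printed from compound 2 to compound 3 (within the scatter) is estimated as roughly flat. Compound 3 is therefore expected to give 1000000 nM, within 300000 nM to 3000000 nM.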

Compound 3, inhibition constant: 1000000 nM
For compound 3 middle estimate and measured number coincide at the digits printed; low and high end bracket the measured number.
By their numbers in this assay, from the lowest: compound 1; then compounds 2 and 3 (each within the scatter of the next).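

In this assay, methoxy in place of hydrogen on this aromatic carbon, ortho to a methoxy group, gives no change at the digits printed from compound 2 to compound 3 (within the scatter) and nothing more. Within the data shown here, the earlier compounds carried no group at this position, so only this pair shows that a methoxy here leaves the number where compound 2 put it. No measurement in hand bears on why.

Still open, going by these compounds, is whether an amine or a carboxylic acid at this position would move the number, and whether methoxy here would behave alike on the core of compound 1, which gives 21300 nM in this assay.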